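This account rests on a few compounds, and the source may have more. Where it says the series, first, only, none or still open, it means among the compounds named here.

Measured so far:
- compound 1, `O=C(NCc1ccc(S(=O)(=O)c2ccccc2)cc1)c1cc2ncccc2s1`: in an ADME assay on microsomes from liver (Mus musculus) for metabolic stability, read by LC-MS, with a stated time of 30 min, tested at 1 uM (a lower number here means that less of the compound is left, a higher number that more of the compound is left), compound 1 gives 1.6%
- compound 2, `O=C(NCc1ccc(S(=O)(=O)c2cc(F)cc(F)c2)cc1)c1cc2cnccc2[nH]1`: in this assay compound 2 gives 63%
- compound 3, `O=C(NCc1ccc(S(=O)(=O)c2ccccc2)cc1)c1cc2ccncc2s1`: in this assay compound 3 gives 21%

Compound 3 stands second highest of the three numbers in this assay; its nearest neighbour is compound 1, whose number is lower beyond the scatter, and compound 2 lies further off, higher beyond the scatter.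

Compound 4 is `O=C(NCc1ccc(S(=O)(=O)c2ccccc2)cc1)c1nc2cnccc2[nH]1`. It differs from compound 3 in one place: a group of 9 heavy atoms (6 carbon, 3 nitrogen; one five-membered aromatic ring with 2 hetero atoms, one six-membered aromatic ring with 1 hetero atom) in place of a group of 9 heavy atoms (7 carbon, 1 nitrogen, 1 sulfur; one five-membered aromatic ring with 1 hetero atom, one six-membered aromatic ring with 1 hetero atom), on a carbonyl carbon.

Among the measured compounds shown here, one measured step bears on this: a number 19.4 percentage points higher from compound 1 to compound 3 (beyond the scatter), where one group of the same size replaced another on the same carbonyl carbon. Compound 2, which also carries a group with one hydrogen-bond donor on that carbonyl carbon, gives the highest of the three numbers, although it has no single-step link to compound 3 and its other end also differs. The change from compound 3 to compound 4 swaps one heteroatom-containing bicycle for another that brings in a hydrogen-bond donor; the step is therefore expected to be upward in this assay, of modest to moderate size, with wide uncertainty.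

Compound 4 is estimated at 45% (range 20% to 75%), an expected step of a number 24 percentage points higher from compound 3 to compound 4 (beyond the scatter).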

Compound 4, percent of the compound remaining: 7.3%
For compound 4 the middle estimate is 37.7 percentage points above the measured one; measured number outside the range, below it.
By their numbers in this assay, from the lowest: compounds 1 and 4 (each within the scatter of the next); then compound 3; then compound 2.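

Within this set, a hydrogen-bond donor on the group at the carbonyl carbon does not go with better survival in this assay: exchanging one group of the same heavy-atom count for the other gives a number 13.7 percentage points lower from compound 3 to compound 4 (beyond the scatter). Among the compounds shown here, the comparison with the other bicycle gives a number 5.7 percentage points higher from compound 1 to compound 4 (within the scatter), so among the three groups on this shared core only the one in compound 3 stands apart, and compounds 1 and 4 cannot be separated. No measurement shown accounts for either step, so the ranking of these groups remains purely empirical.

Compound 2 also carries a donor-bearing group on the carbonyl carbon, but its other end differs too, so the contributions of the two places to its number in this assay cannot be separated. Going by these compounds, it also remains open how a plain phenyl or a morpholine on that carbonyl carbon would behave, and whether the group from compound 4 would give a different number if paired with the other end of compound 2.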